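Replacing Dichlorophenyl by Trifluoromethylphenyl on a Kinase Binder

A few compounds are considered here, and "the series" means these few. Any claim that something is new, unique, unknown or untested is made for them only; others in the source may bear on it.

Compound 3 `CCCS(=O)(=O)Nc1ccc(F)c(C(=O)c2n[nH]c3ncc(-c4cc(Cl)cc(Cl)c4)cc23)c1F` gives 73% in an assay for binding affinity to dual specificity mitogen-activated protein kinase kinase 4 (Homo sapiens), read by KINOMEscan, tested at 100 nM (a lower number here means a stronger effect, a higher number a weaker effect of the compound at the concentration tested), the highest of the three numbers measured, so it shows the weakest effect of the set. Compound 1 `CCCS(=O)(=O)Nc1ccc(F)c(C(=O)c2n[nH]c3ncc(-c4cccc(C)c4)cc23)c1F` gives 15% and compound 2 `CCCS(=O)(=O)Nc1ccc(F)c(C(=O)c2n[nH]c3ncc(-c4ccc(O)cc4)cc23)c1F` gives 0.75%. Two measured steps lead into compound 3: a number 58 percentage points higher from compound 1 to compound 3 (beyond the scatter) and a number 72.3 percentage points higher from compound 2 to compound 3 (beyond the scatter). Compound 4 `CCCS(=O)(=O)Nc1ccc(F)c(C(=O)c2n[nH]c3ncc(-c4cccc(C(F)(F)F)c4)cc23)c1F` differs from compound 3 in one place: 3-(trifluoromethyl)phenyl in place of 3,5-dichlorophenyl on an aromatic carbon. The entering group carries a single substituent, as does the group of compound 1, whereas compound 3 carries two. Among the compounds with values here, a large downward step is therefore expected, though no measured step covers a trifluoromethyl group, and the estimate stays above compound 1. Compound 4 is estimated at 30%, between 8% and 70%, which is expected to mean a number 43 percentage points lower from compound 3 to compound 4 (beyond the scatter).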

Compound 4, a percentage reported as activity, at one concentration (the size of the read-out at that concentration, not a potency): 57%
Beside the measured number, compound 4's estimate is 27 percentage points below it; measured number inside the range.
By their numbers in this assay, from the lowest: compound 2; then compound 1; then compound 4; then compound 3.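

In this assay, a single substituent on the phenyl ring does not by itself restore the effect: dropping from two chlorines to one trifluoromethyl helps only modestly (a number 16 percentage points lower from compound 3 to compound 4 (beyond the scatter)), while trifluoromethyl loses much ground against methyl (a number 42 percentage points higher from compound 1 to compound 4 (beyond the scatter)). The 4-hydroxyphenyl group also keeps a wide lead (a number 56.3 percentage points higher from compound 2 to compound 4 (beyond the scatter)). No measurement here explains these shifts.

Still open, from the compounds shown here alone, is whether 3-chlorophenyl, with one chlorine, would read closer to compound 3 or compound 4. Going by these compounds, it is also open whether an amine or a carboxylic acid could replace the hydroxyl of compound 2 and keep its strong effect.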